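Urea to amide in a pyrazole series at one concentration

The source may report more compounds than this note shows. Statements on the series, on what has been measured and on what is new or still open speak of the compounds shown alone.

Of the compounds shown here, three sharing one core have been measured in a functional assay on COLO 205 cells (Homo sapiens) for inhibition, read by sulforhodamine B assay, with a stated time of 48 h, tested at 1 uM; a lower number here means a stronger effect, a higher number a weaker effect of the compound at the concentration tested. Compound 1 `O=C(Nc1cccc(-n2cc(-c3ccncc3)c(-c3cc(O)cc(Cl)c3)n2)c1)Nc1ccc(Cl)c(C(F)(F)F)c1` gives 99%, compound 2 `O=C(Nc1cccc(-n2cc(-c3ccncc3)c(-c3cc(O)cc(Cl)c3)n2)c1)Nc1ccc(Cl)c(Cl)c1` gives 101%, and compound 3 `COc1cc(Cl)cc(-c2nn(-c3cccc(NC(=O)Nc4ccc(Cl)c(Cl)c4)c3)cc2-c2ccncc2)c1` gives 91%. Compound 3 thus has the lowest of the three numbers, yet its gaps to compound 1 and compound 2 stay within the scatter. The two measured steps, a number 2 percentage points higher from compound 1 to compound 2 (within the scatter) and a number 10 percentage points lower from compound 2 to compound 3 (within the scatter), were both within the scatter and touch other parts of the molecule. Compound 4 `COc1cc(Cl)cc(-c2nn(-c3cccc(NC(=O)c4cccc(C(F)(F)F)c4)c3)cc2-c2ccncc2)c1` differs from compound 3 by 3-(trifluoromethyl)phenyl in place of (3,4-dichlorophenyl)amino on a carbonyl carbon. Within the data shown here, no measured step covers this change, so the expectation for compound 4 in this assay is a number 4 percentage points higher from compound 3 to compound 4 (within the scatter), a step not beyond the scatter, giving an estimated 95% with a range from 80% to 108%.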

Compound 4, a percentage reported as activity, at one concentration (the size of the read-out at that concentration, not a potency): 94%
Estimate against measurement, compound 4: 1 percentage points above; the measured number falls inside the stated range.
By their numbers in this assay, from the lowest: compounds 3, 4, 1 and 2 (each within the scatter of the next).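

In this assay, the change at this carbonyl carbon gives a number 3 percentage points higher from compound 3 to compound 4 (within the scatter). It is the first shown step at this position, and it replaces one whole arm: the ring substituents change, and the hydrogen-bond donor count of the group goes from 1 to 0. Even so, the step does not separate the two compounds, and nothing available explains this result.

Going by these compounds, because both features change together, their separate contributions remain unknown. On these data alone, whether an amine or a carboxylic acid on this ring would move the number beyond the scatter also remains open.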